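Thiosemicarbazone series: cytotoxicity limits and a methylated butyl analogue

A few compounds are considered here, and "the series" means these few. Any claim that something is new, unique, unknown or untested is made for them only; others in the source may bear on it.

Compound 3 `CCCNC(=S)N/N=C\c1c[nH]c2ccccc12` is one of three thiosemicarbazones so far run in an ADME assay on KB cells (Homo sapiens) for cytotoxicity, read by MTT assay, with a stated time of 44 h; a lower number here means a stronger inhibitor, a higher number a weaker inhibitor. In this assay compound 3 gives > 100000 nM, which is a limit of the assay and not a number. Compound 1 `CCCCNC(=S)N/N=C\c1c[nH]c2ccccc12` likewise gives > 100000 nM, again only a limit. Compound 2 `CN(Cc1ccccc1)C(=S)N/N=C\c1c[nH]c2ccccc12` gives > 100000 nM, also a limit. Compound 3 therefore cannot be placed relative to the others: all three values shown sit at the limit of > 100000 nM in this assay, at which 3 of the 3 values shown sit. For the measured compounds named here, the single measured step, a step that the two limits leave unreadable from compound 1 to compound 3, is unreadable for the same reason. Compound 4 `CCCCN(C)C(=S)N/N=C\c1c[nH]c2ccccc12` is not yet measured; it differs from compound 3 by butyl(methyl)amino in place of propylamino on a thiocarbonyl carbon. Going by the values given here, no measured step can be sized for this change; the only guide is that compound 1, which carries the same butyl chain, and compound 2 both sit at the limit. No step beyond the scatter is expected from compound 3 to compound 4, so a step that the limit leaves unreadable from compound 3 to compound 4 is the estimated step. Compound 4 is expected to give 150000 nM, within 50000 nM to 500000 nM, and most likely to be reported only as a limit.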

Compound 4, half-maximal inhibitory concentration: > 100000 nM
Compound 4: no number, only a limit; the forecaster's own chance of this, stated with the estimate: 85%; the middle value does not contradict the limit.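

In this assay compound 4 gives > 100000 nM, a limit of the assay and not a number. The steps from compound 1, compound 2 and compound 3 to compound 4 cannot be read: the limit of > 100000 nM in this assay, at which 4 of the 4 values shown sit. The compounds shown leave open whether any change on the thiocarbonyl carbon shifts cytotoxicity.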